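The source may report more compounds than this note shows. Statements on the series, on what has been measured and on what is new or still open speak of the compounds shown alone.

Measured so far in a functional assay on SK-OV-3 cells (Homo sapiens) for cytotoxicity, read by MTT assay, with a stated time of 48 h; on this read-out lower numbers stand for stronger inhibition and higher numbers for weaker inhibition:

- compound 1 `O=C(/C=C/c1ccc2c(c1)B(O)OC2)c1ccccc1` gives 3400 nM
- compound 2 `O=C(/C=C/c1ccc2c(c1)B(O)OC2)c1cccs1` gives 10400 nM

Among the measured compounds shown here, compound 2 stands at the highest of the two numbers in this assay; the only neighbour is compound 1, and the step between them is a 3.1-fold higher number from compound 1 to compound 2 (0.49 log units; beyond the scatter), which lies beyond the scatter but is modest in size. That step consisted of thiophen-2-yl in place of phenyl on the carbonyl carbon, with the rest of the shared core unchanged.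

Compound 3 `O=C(/C=C/c1ccc2c(c1)B(O)OC2)c1ccc(F)cc1` has not been measured. The change from compound 2 is 4-fluorophenyl in place of thiophen-2-yl on a carbonyl carbon. For the measured compounds named here, the one measured step that bears on it is a 3.1-fold higher number from compound 1 to compound 2 (0.49 log units; beyond the scatter), since the present change returns a six-membered carbon-only ring to the same carbonyl carbon, now carrying a fluorine. The expectation is therefore that most of that step is undone: a lower number for compound 3, by about a 3.0-fold lower number from compound 2 to compound 3 (0.47 log units; beyond the scatter), landing close to compound 1. Whether the fluorine itself shifts the number cannot be judged from the two compounds measured. Compound 3 is estimated at 3500 nM, with a range of 1400 nM to 9000 nM.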

Compound 3, half-maximal inhibitory concentration: 1400 nM
Estimate against measurement, compound 3: 2.5-fold (0.40 log units) above; the range from low to high includes it.
By their numbers in this assay, from the lowest: compound 3; then compound 1; then compound 2.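

In this assay, the group on the carbonyl carbon can move the number down as well as up: fluoro in place of hydrogen on an aromatic carbon gives a 2.4-fold lower number from compound 1 to compound 3 (0.39 log units; beyond the scatter) and so counts on its own, beyond the scatter, which compound 1 and compound 2 could not show. The exchange of thiophen-2-yl for 4-fluorophenyl gives a 7.4-fold lower number from compound 2 to compound 3 (0.87 log units; beyond the scatter) and spans the whole range of the three compounds, with compound 3 lowest and compound 2 highest, so the choice of ring and the substituent on it both bear on the number at this position. No supporting measurement is available to explain either step, and the numbers record only the size and direction of each change.

Open, as far as these compounds go, is whether the drop belongs to fluorine in particular or would also appear with chloro, methoxy or an amine in place of that fluoro. Also open, from the compounds shown here alone, is how a nitrogen-containing ring such as pyridin-3-yl on the carbonyl carbon would compare with the phenyl and thiophen-2-yl rings, and whether a fluoro on that ring would give a step of similar size.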